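From a Long Ester Chain to a Small Acetyl Group

This account rests on a few compounds, and the source may have more. Where it says the series, first, only, none or still open, it means among the compounds named here.

Compound 2 `CCOC(=O)/C=C/CO/N=C(/c1ccc(OC)c(OC)c1OC)c1cccc2ccccc12` sits at the edge of what a functional assay on MCF7 cells (Homo sapiens) for inhibition, read by sulforhodamine B assay, with a stated time of 48 h (on this read-out higher numbers stand for weaker inhibition and lower numbers for stronger inhibition), can report: in this assay compound 2 gives > 20000 nM, which is a limit of the assay rather than a number. Compound 1 `CCOC(=O)CCO/N=C(/c1ccc(OC)c(OC)c1OC)c1cccc2ccccc12` likewise gives > 20000 nM in this assay, again a limit. The step that the two limits leave unreadable from compound 1 to compound 2 therefore has no readable size, and the limit of > 20000 nM in this assay, at which 2 of the 2 values shown sit, is the whole of the evidence on it. Compound 3 `COc1ccc(/C(=N/OC(C)=O)c2cccc3ccccc23)c(OC)c1OC` differs from compound 2 by acetyl in place of 3-(ethoxycarbonyl)prop-2-en-1-yl on an oxygen. Going by the values given here, no measured step of readable size bears on this change, so the expectation for compound 3 rests only on where compound 2 stands, at the limit, with no movement beyond the scatter assumed in either direction in this assay. Compound 3 is expected at 25000 nM, with a range from 10000 nM to 60000 nM. The implied step that the limit leaves unreadable from compound 2 to compound 3 is expected to be essentially flat.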

Compound 3, half-maximal inhibitory concentration: > 20000 nM
Compound 3: a limit, no number; the forecaster's own chance of this, stated with the estimate: 75%; the middle value is on the limit's open side.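

In this assay no step among compound 1, compound 2 and compound 3 can be read, because all three stand at a limit and not at a number: the limit of > 20000 nM in this assay, at which 3 of the 3 values shown sit.

The compounds shown leave open how strongly any of the three inhibits, and whether any of these chain changes alters inhibition at all.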